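Swapping the aryl amide cap for a chloroacetyl group

A few compounds are considered here, and "the series" means these few. Any claim that something is new, unique, unknown or untested is made for them only; others in the source may bear on it.

Measured so far:
Compound 1, `COc1ccc(CNC(=O)CSc2nc3ccc(NC(=O)c4ccc(Cl)cc4)cc3s2)cc1`, gives 7400 nM.
Compound 2, `O=C(CSc1nc2ccc(NC(=O)c3ccc(Cl)cc3)cc2s1)NCc1ccc(Cl)cc1`, gives 17800 nM.
Compound 3, `CNC(=O)CSc1nc2ccc(NC(=O)c3ccc(Cl)cc3)cc2s1`, gives 15300 nM.

These three compounds share one core and were compared in a functional assay on HepG2 cells (Homo sapiens) for cytotoxicity, read by MTT assay, with a stated time of 48 h; a higher number here means a weaker inhibitor, a lower number a stronger inhibitor. Compound 2 has the highest number of the three: against compound 1 the step is a 2.4-fold higher number from compound 1 to compound 2 (0.38 log units; beyond the scatter), while compound 2 and compound 3 sit close together, as a 1.2-fold lower number from compound 2 to compound 3 (0.07 log units; within the scatter) shows.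

The unmeasured compound 4, `O=C(CSc1nc2ccc(NC(=O)CCl)cc2s1)NCc1ccc(Cl)cc1`, is reached from compound 2 by chloromethyl in place of 4-chlorophenyl on a carbonyl carbon. All three measured steps change the other end of the molecule, the group on the saturated chain carbon bound to the amide-type nitrogen: a 2.4-fold higher number from compound 1 to compound 2 (0.38 log units; beyond the scatter), a 2.1-fold higher number from compound 1 to compound 3 (0.32 log units; beyond the scatter) and a 1.2-fold lower number from compound 2 to compound 3 (0.07 log units; within the scatter). Among the compounds with values here, none of them touches the carbonyl carbon altered here, so no measured step bears directly on this change, and the measured steps were modest at most. The expectation for compound 4 is therefore uncertain and rests on the size of the structural change alone, with a step of a 2.2-fold lower number from compound 2 to compound 4 (0.35 log units; beyond the scatter) thought likely. In this assay compound 4 is estimated at 8000 nM, with a range from 2000 nM to 30000 nM.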

Compound 4, half-maximal inhibitory concentration: 1800 nM
Beside the measured number, compound 4's estimate is 4.4-fold (0.65 log units) above it; the measured number lies below the stated range.
By their numbers in this assay, from the lowest: compound 4; then compound 1; then compounds 3 and 2 (each within the scatter of the next).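

This is the first change shown at the carbonyl carbon, and in this assay chloromethyl in place of 4-chlorophenyl gives a 9.9-fold lower number from compound 2 to compound 4 (1.00 log units; beyond the scatter) and so moves the number more than the earlier change of a 2.4-fold higher number from compound 1 to compound 2 (0.38 log units; beyond the scatter) did. The smaller group has no ring, yet it gives the lower number, so the six-membered aromatic ring of 4-chlorophenyl is not needed at this position for a low number in these cells. Nothing measured here explains why the number falls.

Compound 4 loses the ring but keeps a chlorine, so the compounds shown leave open whether the drop comes from losing 4-chlorophenyl or from gaining chloromethyl in particular; a plain methyl group on the same carbonyl carbon would help separate the two. Also open, on these data alone, is whether the same swap would give a step of similar size on compound 1 or compound 3, which carry different groups on the saturated chain carbon bound to the amide-type nitrogen.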